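Cytotoxicity Estimate for Compound 4 from Three Analogues

The source may report more compounds than this note shows. Statements on the series, on what has been measured and on what is new or still open speak of the compounds shown alone.

Compound 1, `CC(Sc1nnc(-c2ccncc2)s1)C(=O)Nc1ccc(Cl)cc1`: > 50000 nM in an ADME assay on BHK-21 cells (Mesocricetus auratus) for cytotoxicity, with a stated time of 3 days (a lower number here means that less compound is tolerated, a higher number that more compound is tolerated), a limit of the assay.
Compound 2, `O=C(CSc1nnc(-c2ccncc2)s1)Nc1ccc(Cl)cc1Cl`: "not determined" (no result reported) in this assay.
Compound 3, `O=C(CSc1nnc(-c2ccncc2)s1)NCc1ccc(Cl)cc1`: > 50000 nM in this assay, a limit of the assay.

Compound 3 stands only at a limit in this assay, so it cannot be placed above or below its neighbours. Compound 1 sits at the same limit. Compound 2 has no result at all. The change from compound 3 to compound 4, `O=C(CSc1nnc(-c2ccncc2)s1)Nc1ccc(Cl)cc1`, is 4-chlorophenyl in place of 4-chlorobenzyl on an amide-type nitrogen. No measured step connects any two of these compounds, so nothing here shows how the group on the amide-type nitrogen moves this read-out. Given (the limit of > 50000 nM in this assay, at which 2 of the 3 values shown sit), the step is expected to stay within the scatter and to carry no direction; the step from compound 3 to compound 4 is estimated as a number no higher from compound 3 to compound 4 (the limit leaves the size open). Compound 4 is therefore expected to give 50000 nM, between 20000 nM and 100000 nM, most likely reported once more as a limit rather than a number.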

Compound 4, half-maximal cytotoxic concentration: > 50000 nM
Compound 4 gave a limit, no number; the forecaster's own chance of this, stated with the estimate: 85%; the middle value sits exactly at the limit.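

Neither step to compound 4, from compound 3 or from compound 1, can be read in this assay, because all three compounds stand at a limit of the assay: the limit of > 50000 nM in this assay, at which 3 of the 4 values shown sit.

The compounds shown leave open whether the group on the amide-type nitrogen, or the methyl on the saturated chain carbon, moves the read-out at all.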